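The compounds below may be only part of what the source reports. "The series", "measured", "known", "first", "only" and "open" are said of these compounds alone.

Measured compounds:
compound 1 `CCCN(c1c(OC)nn2c(-c3c(OC)cc(COC)cc3OC)csc12)C1CCOCC1` — 98 nM
compound 2 `COCc1cc(OC)c(-c2csc3c(N(CCC4CC4)C4CCOCC4)c(OC)nn23)c(OC)c1` — 83 nM

In an assay on HEK293 cells for displacement of a labelled ligand from corticotropin-releasing factor receptor 1 (Homo sapiens), read by scintillation proximity assay, with a stated time of 2 h (a higher number here means a weaker inhibitor, a lower number a stronger inhibitor), compound 1 gives 98 nM, the highest of the two numbers shown, while compound 2 gives 83 nM. Going by the values given here, the only measured step, a 1.2-fold lower number from compound 1 to compound 2 (0.07 log units; within the scatter), is within the scatter, so the two compounds cannot be ranked.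

Compound 3 `CCCN(c1c(OC)nn2c(-c3c(OC)cc(COCC)cc3OC)csc12)C1CCOCC1` differs from compound 1 by methyl in place of hydrogen on a saturated chain carbon bound to an oxygen on a saturated carbon. Among the compounds with values here, no measured step touches this part of the molecule: the one step known, from compound 1 to compound 2, concerns the chain on the ring nitrogen and was small in any case. There is therefore no basis for expecting a shift beyond the scatter in this assay, and the small size of the change argues the same way. Compound 3 is expected to give about 100 nM, between 45 nM and 220 nM, an expected step of a 1.0-fold higher number from compound 1 to compound 3 (0.01 log units; within the scatter).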

Compound 3, half-maximal inhibitory concentration: 65 nM
Estimate against measurement, compound 3: 1.5-fold (0.19 log units) above; low and high end bracket the measured number.
By their numbers in this assay, from the lowest: compounds 3, 2 and 1 (each within the scatter of the next).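

In this assay, going from methoxymethyl to ethoxymethyl gives a 1.5-fold lower number from compound 1 to compound 3 (0.18 log units; within the scatter). This position, which the earlier step on the chain at the nitrogen did not touch, therefore takes methyl in place of hydrogen on a saturated chain carbon bound to an oxygen on a saturated carbon with no shift that can be told from the scatter. Going by these compounds alone, no supporting data bear on this result, and like the earlier step it gives no ranking of the compounds.

The compounds shown leave open whether a longer chain such as propoxymethyl, or an amine or a carboxylic acid in place of the ethoxymethyl, would move the number beyond the scatter. They also leave open whether ethoxymethyl and the cyclopropyl of compound 2 would together give a step larger than the scatter.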